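This account rests on a few compounds, and the source may have more. Where it says the series, first, only, none or still open, it means among the compounds named here.

Measured compounds in an ADME assay on Vero cells (Chlorocebus sabaeus) for cytotoxicity, read by neutral red uptake, tested at 49 ug/mL; a lower number here means a stronger effect, a higher number a weaker effect of the compound at the concentration tested:
- compound 1 `O=C1CSC(c2cccc(Cl)c2)N1CCN1CCCCC1`: 100%
- compound 2 `O=C1CSC(c2ccc([N+](=O)[O-])cc2)N1CCN1CCCCC1`: 100%
- compound 3 `O=C1CSC(c2ccc(F)cc2)N1CCN1CCCCC1`: 100%

Compound 3 stands level with compounds 1 and 2 at the digits shown. The step of no change at the digits printed from compound 1 to compound 3 (within the scatter) and the step of no change at the digits printed from compound 2 to compound 3 (within the scatter) both stay within the scatter, so neither the change of the aryl group nor the swap on the aromatic carbon moved the read-out in this assay. Every measured compound of the series sits at the same reading.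

Compound 4 `O=C1CSC(c2ccc(Cl)cc2)N1CCN1CCCCC1` is not yet measured. Relative to compound 3 the difference is chloro in place of fluoro on an aromatic carbon; the group exchanged sits on an aromatic carbon of a six-membered aromatic ring of carbon only. The two measured steps bear on it: the step from compound 1 to compound 3 exchanged a halogenated aryl group, the step from compound 2 to compound 3 exchanged one group on the aromatic carbon, and both left the reading unchanged. No step beyond the scatter is therefore expected in this assay, and compound 4 is expected at 100%, between 85% and 100%. The expected step is no change at the digits printed from compound 3 to compound 4 (within the scatter).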

Compound 4, a percentage reported as activity, at one concentration (the size of the read-out at that concentration, not a potency): 84%
Estimate against measurement, compound 4: 16 percentage points above, and the stated range ends above it.
By their numbers in this assay, from the lowest: compound 4; then compounds 1, 2 and 3 (each within the scatter of the next).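

In this assay, for the compounds shown here, the aromatic carbon para to a large group is the first place where one exchange moves the reading: chloro in place of fluoro gives a clear step (a number 16 percentage points lower from compound 3 to compound 4 (beyond the scatter)), and chloro in place of nitro on that carbon gives another (a number 16 percentage points lower from compound 2 to compound 4 (beyond the scatter)). The location of the chlorine also matters, which the level earlier compounds could not show, as 4-chlorophenyl in place of 3-chlorophenyl also shifts the reading (a number 16 percentage points lower from compound 1 to compound 4 (beyond the scatter)). No measured property of these compounds is at hand to account for these steps.

On these data alone, the effect rests on compound 4 alone, so it remains open whether it is specific to chloro or extends to bromo on the same carbon. Equally open, as far as these compounds go, is how a methoxy, an amine or a carboxylic acid there would read.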